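Removing a methoxy group from an indole-type sulfonyl acrylonitrile

This account rests on a few compounds, and the source may have more. Where it says the series, first, only, none or still open, it means among the compounds named here.

Of the compounds shown here, two from this series have been measured in a functional assay on K562 cells (Homo sapiens) for inhibition, read by sulforhodamine B assay, with a stated time of 48 h; on this read-out lower numbers stand for stronger inhibition of growth and higher numbers for weaker inhibition of growth. Compound 1, with structure `CC(=O)/C(=C\c1c(-c2ccccc2)[nH]c2ccccc12)S(=O)(=O)c1ccccc1`, gives 442 nM in this assay. Compound 2, with structure `COc1ccc2[nH]c(-c3ccccc3)c(/C=C(\C#N)S(=O)(=O)c3ccccc3)c2c1`, gives 1400 nM in this assay, and this is the higher of the two numbers shown, with compound 1 giving the lower one; the gap between them lies beyond the usual scatter.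

Compound 3, with structure `N#C/C(=C\c1c(-c2ccccc2)[nH]c2ccccc12)S(=O)(=O)c1ccccc1`, has not yet been measured. It differs from compound 2 in one place: hydrogen in place of methoxy on an aromatic carbon. Among the measured compounds shown here, no measured pair in this set shows the effect of this exact change, so the direction of the step is open. Compound 1, which also lacks the methoxy group but carries a different group on the side chain, gives the lower number, so a modest step toward a lower number for compound 3 is expected, one that may not exceed the scatter. The estimated step from compound 2 to compound 3 is a 1.8-fold lower number from compound 2 to compound 3 (0.24 log units; within the scatter). Compound 3 is expected to give about 800 nM in this assay, within a range from 250 nM to 2500 nM.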

Compound 3, concentration for 50% growth inhibition: 348 nM
Compound 3: middle estimate off by 2.3-fold (0.36 log units), on the high side, and the stated range covers the measured number.
By their numbers in this assay, from the lowest: compounds 3 and 1 (each within the scatter of the next); then compound 2.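

In this assay, among the compounds shown here, replacing the methoxy group on this aromatic carbon with hydrogen gives a 4.0-fold lower number from compound 2 to compound 3 (0.60 log units; beyond the scatter), the first direct reading of this change, and a step that lies beyond the scatter. With hydrogen at this position in both compounds, placing cyano where acetyl stood on the side chain gives a 1.3-fold lower number from compound 1 to compound 3 (0.10 log units; within the scatter), so these two side-chain groups cannot be told apart on this read-out. The data at hand offer no measurement that could explain the step from methoxy to hydrogen.

The compounds shown leave open whether removing the methoxy group would produce a similar step when acetyl rather than cyano sits on the side chain, as the only methoxy compound here, compound 2, carries cyano. They also leave open how other groups on this same aromatic carbon, such as a fluorine atom, a hydroxyl group or an amine, would compare with methoxy and hydrogen, and so whether the step reflects something particular to methoxy or would appear with any group there.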